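Adding a Third Methoxy to Compound 3

A few compounds are considered here, and "the series" means these few. Any claim that something is new, unique, unknown or untested is made for them only; others in the source may bear on it.

Values in a functional assay on DU-145 cells (Homo sapiens) for cytotoxicity, read by MTT assay, with a stated time of 48 h; a higher number here means a weaker inhibitor, a lower number a stronger inhibitor:
Compound 1 `COc1cc(OC)c(OC)cc1/C=C/C(=O)/C=C/c1cc2ccccc2nc1Oc1ccccc1`: 9220 nM
Compound 2 `COc1ccc(/C=C/C(=O)/C=C/c2cc3ccccc3nc2Oc2cccc(Cl)c2)c(OC)c1`: > 10000 nM, a limit of the assay
Compound 3 `COc1ccc(OC)c(/C=C/C(=O)/C=C/c2cc3ccccc3nc2Oc2cccc(Cl)c2)c1`: > 10000 nM, a limit of the assay

Compound 3 has no number in this assay, only the limit > 10000 nM. The same holds across the series, which shows (the limit of > 10000 nM in this assay, at which 2 of the 3 values shown sit). Compound 4 `COc1cc(OC)c(OC)cc1/C=C/C(=O)/C=C/c1cc2ccccc2nc1Oc1cccc(Cl)c1` differs from compound 3 by one change: methoxy in place of hydrogen on an aromatic carbon. This turns the 2,5-dimethoxyphenyl group into the 2,4,5-trimethoxyphenyl group.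

Little measured evidence bears on this change. The only measured step among these methoxy patterns is a step that the two limits leave unreadable from compound 2 to compound 3, so it offers no size to carry over. Compound 4 carries the same 2,4,5-trimethoxyphenyl group as compound 1, which is the only one of the three with a number, 9220 nM. On that single value, a small shift toward stronger inhibition is expected, though compound 4 may well also report only a limit. The expected change is an at least 1.1-fold lower number from compound 3 to compound 4 (0.04 log units; that floor lies within the scatter), an estimate that remains loose without a number for compound 3. For compound 4 the estimated value is 9000 nM, with an expected range from 3500 nM to 20000 nM.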

Compound 4, half-maximal inhibitory concentration: > 10000 nM
Compound 4 gave a limit, no number (the forecaster's own chance of this, stated with the estimate: 55%); middle value at least 1.1-fold (0.04 log units) from the limit.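

In this assay compound 4 gives only a limit of the assay, > 10000 nM, so the third methoxy does not bring the chloro-bearing compounds to a number. The steps from compound 2 and compound 3 to compound 4 cannot be read, and the series now sits even more at the limit: the limit of > 10000 nM in this assay, at which 3 of the 4 values shown sit.

Among these compounds, the one readable step holds the 2,4,5-trimethoxyphenyl group fixed and puts chloro in place of hydrogen on an aromatic carbon, giving an at least 1.0-fold higher number from compound 1 to compound 4 (0.03 log units; that floor lies within the scatter).

Going by these compounds, how far compound 2, compound 3 and compound 4 lie beyond the limit remains open, and with it whether the added methoxy changes their strength at all. Also open, on these data alone, is whether an amine or a hydroxyl group in place of this methoxy would give a readable number in this assay.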